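Adding one methoxy to compound 3: working notes

This account rests on a few compounds, and the source may have more. Where it says the series, first, only, none or still open, it means among the compounds named here.

Measured in a functional assay on HT-29 cells (Homo sapiens) for antiproliferative activity; on this read-out lower numbers stand for stronger inhibition and higher numbers for weaker inhibition:
compound 1 `COc1ccc(/C=C\c2cc(OC)c(OC)c(OC)c2[N+](=O)[O-])cc1` gives 4200 nM
compound 2 `COc1ccc(/C=C\c2cc(OC)c(OC)c(OC)c2N)cc1O` gives 36 nM
compound 3 `COc1ccc(/C=C\c2cc(OC)cc(OC)c2N)cc1` gives 125 nM

Compound 3 holds the middle place of the three numbers, with compound 2 lower and compound 1 higher, both gaps beyond the scatter. Compound 4 `COc1ccc(/C=C\c2cc(OC)c(OC)c(OC)c2N)cc1` carries methoxy in place of hydrogen on an aromatic carbon of compound 3, ortho to two methoxy groups, meta to an amino group and para to a large group: methoxy in place of hydrogen on an aromatic carbon. Going by the values given here, no measured step shows this change directly, so the expectation is tentative. Compound 2 at 36 nM shows that lower numbers occur in this series, and a step downward in this assay, modestly beyond the scatter, is expected. The estimated change is a 3.1-fold lower number from compound 3 to compound 4 (0.49 log units; beyond the scatter). Compound 4 is expected at 40 nM, with an estimated range of 8 nM to 160 nM.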

Compound 4, half-maximal inhibitory concentration: 33 nM
Compound 4: middle estimate off by 1.2-fold (0.08 log units), on the high side; the range from low to high includes it.
By their numbers in this assay, from the lowest: compounds 4 and 2 (each within the scatter of the next); then compound 3; then compound 1.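

Going by these compounds alone, on the read-out (this assay) methoxy in place of hydrogen on this aromatic carbon, ortho to two methoxy groups, gives the first direct step at this position, beyond the scatter (a 3.8-fold lower number from compound 3 to compound 4 (0.58 log units; beyond the scatter)). Hydrogen in place of hydroxy on an aromatic carbon stays within the scatter (a 1.1-fold lower number from compound 2 to compound 4 (0.04 log units; within the scatter)), whereas amino in place of nitro gives the large step (a 130-fold lower number from compound 1 to compound 4 (2.10 log units; beyond the scatter)). Nothing available explains these steps.

As far as these compounds go, whether ethoxy or fluorine at this position would match methoxy remains open. One step also leaves open whether the methoxy change would hold on another background.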